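Replacing pyridin-3-yl with 4-bromophenyl in compound 2

The source may report more compounds than this note shows. Statements on the series, on what has been measured and on what is new or still open speak of the compounds shown alone.

Compound 1 `O=c1cc(-n2cc(-c3ccccc3)nn2)c2cc(Br)ccc2o1` - 11200 nM
Compound 2 `O=c1cc(-n2cc(COc3cccnc3)nn2)c2cc(Br)ccc2o1` - 24800 nM
Compound 3 `O=c1cc(-n2cc(COc3ccc(Br)cc3)nn2)c2cc(Br)ccc2o1` - not yet measured

Within the data shown here, in a functional assay on A549 cells (Homo sapiens) for antiproliferative activity, read by MTT assay, with a stated time of 48 h (on this read-out lower numbers stand for stronger inhibition and higher numbers for weaker inhibition), compound 2 gives 24800 nM and holds the higher of the two numbers so far, with compound 1 as its only neighbour. Compound 3 carries 4-bromophenyl in place of pyridin-3-yl on an oxygen on a saturated carbon. Among the measured compounds shown here, one measured step bears on this change. It is a 2.2-fold higher number from compound 1 to compound 2 (0.35 log units; beyond the scatter) and came with ((pyridin-3-yl)oxy)methyl in place of phenyl on an aromatic carbon. That step is modest but beyond the scatter, and it is only indirect evidence, since it alters more than the ring on the oxygen. For the measured compounds named here, no measured compound shows what 4-bromophenyl does on its own. On the strength of that single step, a modest move to a lower number is expected in this assay, estimated as a 1.9-fold lower number from compound 2 to compound 3 (0.28 log units; within the scatter) (with a wide margin). For compound 3 the estimated value is 13000 nM (expected range 5500 nM to 30000 nM).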

Compound 3, half-maximal inhibitory concentration: 24500 nM
For compound 3 the middle estimate is 1.9-fold (0.28 log units) below the measured one; the measured number falls inside the stated range.
By their numbers in this assay, from the lowest: compound 1; then compounds 3 and 2 (each within the scatter of the next).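

In this assay the exchange of pyridin-3-yl for 4-bromophenyl on an oxygen on a saturated carbon gives a 1.0-fold lower number from compound 2 to compound 3 (0.01 log units; within the scatter) and so leaves the two compounds indistinguishable, although the ring nitrogen and its hydrogen-bond acceptor give way to a carbon-only ring bearing bromine. The earlier step, a 2.2-fold higher number from compound 1 to compound 2 (0.35 log units; beyond the scatter) could not separate the ring on the oxygen from the rest of the change, whereas this pair shows that, for these two rings, the identity of the ring makes no difference that this read-out can resolve, and compound 3 at 24500 nM does not reach the printed value of compound 1 at 11200 nM in this assay. No evidence is at hand that speaks to the reason for this result.

The compounds shown leave open whether an amine or a carboxylic acid on the ring at this position would shift the number at all, since both rings here are unsubstituted or carry only bromine. They also leave open whether a longer chain carrying the ring on the oxygen, or a saturated ring such as morpholine in its place, would behave any differently.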